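A few compounds are considered here, and "the series" means these few. Any claim that something is new, unique, unknown or untested is made for them only; others in the source may bear on it.

Measured so far:
compound 1 `O=C(CN1CCN(c2nnc(Cc3ccccc3)c3ccccc23)CC1)Nc1c(F)cccc1F` gives 19700 nM in a functional assay on HT-29 cells (Homo sapiens) for cytotoxicity, read by MTT assay, with a stated time of 72 h; a higher number here means a weaker inhibitor, a lower number a stronger inhibitor;
compound 2 `O=C(CN1CCN(c2nnc(Cc3ccncc3)c3ccccc23)CC1)Nc1cc(C(F)(F)F)ccc1Cl` gives 4810 nM in this assay.

Compound 1 stands highest of these two numbers, and its gap to compound 2 lies beyond the scatter. Compound 3 `O=C(CN1CCN(c2nnc(Cc3ccccc3)c3ccccc23)CC1)Nc1ccc(F)c(Cl)c1` differs from compound 1 in one place: 3-chloro-4-fluorophenyl in place of 2,6-difluorophenyl on an amide-type nitrogen. Going by the values given here, no pair of measured compounds isolates this change, so no firm footing exists. Compound 3 is expected to give a somewhat lower number than compound 1. The expected step is modest, a 1.6-fold lower number from compound 1 to compound 3 (0.22 log units; within the scatter), and may not exceed the scatter. The estimate for compound 3 is 12000 nM, ranging from 4000 nM to 35000 nM.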

Compound 3, half-maximal inhibitory concentration: 13300 nM
Beside the measured number, compound 3's estimate is 1.1-fold (0.04 log units) below it; the range from low to high includes it.
By their numbers in this assay, from the lowest: compound 2; then compounds 3 and 1 (each within the scatter of the next).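

Placing 3-chloro-4-fluorophenyl where 2,6-difluorophenyl stood on the amide-type nitrogen gives a 1.5-fold lower number from compound 1 to compound 3 (0.17 log units; within the scatter) in this assay, so this assay cannot tell these two halogen-bearing phenyl groups apart on the core of compound 1. Going by these compounds alone, this is the first direct reading at this position, and it shows that this particular exchange of groups leaves no clear difference. Nothing measured here offers an explanation for this result. Still open, on these data alone, is whether an unsubstituted phenyl, or a phenyl carrying an amine or a carboxylic acid, would give a difference beyond the scatter at this position. As far as these compounds go, it is also open whether the same exchange would read alike on a compound with a different group elsewhere.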